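This account rests on a few compounds, and the source may have more. Where it says the series, first, only, none or still open, it means among the compounds named here.

Of the compounds shown here, three that share one core have been measured in a functional assay on isolated protein for inhibition of Glucose-dependent insulinotropic receptor (Rattus norvegicus), read by HTRF and cAMP accumulation; a lower number here means that less compound is needed, a higher number that more compound is needed for the effect. Compound 1 `Cc1nc(S(C)(=O)=O)ccc1Oc1ncnc(OC2CCN(C(=O)O[C@@H](C)CF)CC2)c1F` gives 1680 nM, compound 2 `Cc1nc(S(C)(=O)=O)ccc1Oc1ncnc(OC2CCN(C(=O)O[C@H](C)C(F)(F)F)CC2)c1F` gives 110 nM, and compound 3 `Cc1nc(S(C)(=O)=O)ccc1Oc1ncnc(OC2CCN(C(=S)OC(C)C)CC2)c1F` gives 1050 nM. Compound 3 thus stands close to compound 1, as a 1.6-fold lower number from compound 1 to compound 3 (0.20 log units; within the scatter) shows, and well above compound 2, as a 9.5-fold higher number from compound 2 to compound 3 (0.98 log units; beyond the scatter) shows; the one large movement in this set, a 15-fold lower number from compound 1 to compound 2 (1.18 log units; beyond the scatter), came from adding fluorine to the side chain on the ring nitrogen.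

Compound 4 `Cc1nc(S(C)(=O)=O)ccc1Oc1ncnc(OC2CCN(C(=O)C(C)(C)F)CC2)c1F` is not yet measured. It differs from compound 3 in that (a group of 6 heavy atoms (4 carbon, 1 oxygen, 1 fluorine; no ring) in place of a group of 6 heavy atoms (4 carbon, 1 oxygen, 1 sulfur; no ring), on an amine nitrogen in a ring). For the measured compounds named here, no measured pair makes exactly this exchange, so the earlier steps give only a rough guide: the position is the same one that was varied in the steps from compound 1 to compound 3 and from compound 2 to compound 3, and fluorine enters, as in the step from compound 1 to compound 2. On this basis compound 4 is expected to give about 600 nM in this assay, likely between 150 nM and 2500 nM, which would mean an expected step of a 1.8-fold lower number from compound 3 to compound 4 (0.24 log units; within the scatter).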

Compound 4, half-maximal effective concentration: 296 nM
Beside the measured number, compound 4's estimate is 2.0-fold (0.31 log units) above it; the range from low to high includes it.
By their numbers in this assay, from the lowest: compound 2; then compound 4; then compounds 3 and 1 (each within the scatter of the next).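

With (1-fluoro-1-methylethyl)carbonyl on the amine nitrogen in the ring, the side chain reaches the carbonyl carbon directly, with no oxygen link, and this form is compatible with a lower number than that of the sulfur-containing group, a 3.5-fold lower number from compound 3 to compound 4 (0.55 log units; beyond the scatter). Compounds 1 and 4 each carry a single fluorine in this side chain, yet the change between them is also beyond the scatter, a 5.7-fold lower number from compound 1 to compound 4 (0.75 log units; beyond the scatter), so the fluorine count alone does not set the number at this position. The trifluoromethyl-bearing group of compound 2 still gives the lowest number, a 2.7-fold higher number from compound 2 to compound 4 (0.43 log units; beyond the scatter).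

Nothing available here explains these steps. Going by these compounds, it also remains open how the same side chain without its fluorine, a plain 2-methylpropanoyl group, or an amine on the carbonyl carbon would read in this assay.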